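Removing the terminal phosphate from a brominated uridine triphosphate

The compounds below may be only part of what the source reports. "The series", "measured", "known", "first", "only" and "open" are said of these compounds alone.

Measured compounds:
- Compound 1 `O=c1ccn([C@@H]2O[C@H](COP(=O)(O)OP(=O)(O)OP(=O)(O)O)[C@@H](O)[C@H]2O)c(=S)[nH]1`: 1770 nM
- Compound 2 `O=c1[nH]c(=O)n([C@@H]2O[C@H](COP(=O)(O)OP(=O)(O)OP(=O)(O)O)[C@@H](O)[C@H]2O)cc1Br`: 3460 nM

The two measured compounds share the same sugar and triphosphate chain and differ only in the base. In an in vitro functional assay on 1321-N1 cells for agonist activity at P2Y purinoceptor 4 (Homo sapiens) (a higher number here means that more compound is needed for the effect, a lower number that less compound is needed), compound 1 gives 1770 nM. Compound 2, with a brominated base in place of the thio-substituted base, gives 3460 nM, the step being a 2.0-fold higher number from compound 1 to compound 2 (0.29 log units; within the scatter). Compound 2 therefore stands at the higher of the two numbers, but the difference to compound 1 lies within the scatter, so the two cannot be ordered.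

Compound 3 `O=c1[nH]c(=O)n([C@@H]2O[C@H](COP(=O)(O)OP(=O)(O)O)[C@@H](O)[C@H]2O)cc1Br` keeps the brominated base of compound 2 and changes the phosphate chain instead: a hydrogen atom in place of a group of 4 heavy atoms (3 oxygen, 1 phosphorus; no ring), on an oxygen. Going by the values given here, none of the measured steps touches the phosphate chain; the only step known alters the base. Among the compounds with values here, there is thus no measured step that bears on this change, and the expected direction and size rest on no comparable pair. The estimate for compound 3 is kept broad accordingly: an expected value of 15000 nM, within a range of 2000 nM to 100000 nM, which is an expected step of a 4.3-fold higher number from compound 2 to compound 3 (0.64 log units; beyond the scatter).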

Compound 3, half-maximal effective concentration: 7200 nM
For compound 3 the middle estimate is 2.1-fold (0.32 log units) above the measured one, and the stated range covers the measured number.
By their numbers in this assay, from the lowest: compounds 1 and 2 (each within the scatter of the next); then compound 3.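

Going by these compounds alone, until this point only the base had changed, so this is the first reading on the phosphate chain: in this assay, putting a hydrogen atom on this oxygen in place of the group of 4 heavy atoms gives a 2.1-fold higher number from compound 2 to compound 3 (0.32 log units; beyond the scatter) and so moves the number in a modest step that lies beyond the scatter. Within the data shown here, the group that leaves therefore counts for something at this position, yet the change costs only a small shift, and compound 3 still gives a measurable number in the same range as the earlier compounds. The compounds shown contain nothing that explains why the number moves in this direction or by this amount.

Among these compounds, one open question is whether the same change would give a step of similar size on a different base, such as the one in compound 1, since only the brominated base has been seen with both chains. Also open, as far as these compounds go, is what would happen with another group on this oxygen, such as a methyl group, or with a longer phosphate chain.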